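Tetrahydropyran series: cytotoxicity on HeLa cells, working notes

The source may report more compounds than this note shows. Statements on the series, on what has been measured and on what is new or still open speak of the compounds shown alone.

Measured compounds:
compound 1, `COc1ccc([C@@H]2OC[C@H]([C@@H](O)c3ccc(OC)c(OC)c3)C[C@H]2C/C=C/c2ccc(OC)c(OC)c2)cc1`, 29200 nM
compound 2, `Oc1ccccc1/C=C/C[C@H]1C[C@@H]([C@@H](O)c2ccccc2)CO[C@@H]1c1ccccc1`, 21800 nM
compound 3, `COc1ccc(/C=C/C[C@@H]2C[C@H]([C@H](O)c3ccc(OC)c(OC)c3)CO[C@H]2c2ccc(OC)c(OC)c2)cc1OC`, 28700 nM

All three values come from a functional assay on HeLa cells (Homo sapiens) for cytotoxicity, read by WST assay, with a stated time of 48 h; a higher number here means a weaker inhibitor, a lower number a stronger inhibitor. Compound 2 holds the lowest of the three numbers, but its gaps to compound 3 and to compound 1 both lie within the usual scatter of the measurement, so no order among the three can be read from these values. The series as it stands is flat: compounds carrying methoxy-substituted aryl groups and the compound carrying an unsubstituted phenyl with a 2-hydroxyphenyl on the chain all give numbers of the same size.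

The next compound to be measured is compound 4, `Cc1ccc(/C=C/C[C@H]2C[C@@H]([C@@H](O)c3ccccc3)CO[C@@H]2c2ccccc2)cc1C`. Relative to compound 2 the change is 3,4-dimethylphenyl in place of 2-hydroxyphenyl on a double-bonded chain carbon bound to a double-bonded chain carbon. Among the compounds with values here, no pair of measured compounds differs at this one place, so there is no measured step to lean on. Given that compound 1, compound 2 and compound 3 all sit within the scatter of one another despite different aryl substitution, the step is expected to be small, with no clear direction, and a 1.1-fold higher number from compound 2 to compound 4 (0.06 log units; within the scatter) is the estimated change. Compound 4 is thus expected to give 25000 nM in this assay, with a range from 10000 nM to 60000 nM.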

Compound 4, half-maximal inhibitory concentration: 10000 nM
Beside the measured number, compound 4's estimate is 2.5-fold (0.40 log units) above it, and the stated range covers the measured number.
By their numbers in this assay, from the lowest: compound 4; then compounds 2, 3 and 1 (each within the scatter of the next).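

In this assay, within the data shown here, the change from 2-(2-hydroxyphenyl)ethenyl to 2-(3,4-dimethylphenyl)ethenyl gives a 2.2-fold lower number from compound 2 to compound 4 (0.34 log units; beyond the scatter) and is the only step read so far, so the aryl group on a double-bonded chain carbon bound to a double-bonded chain carbon does move the number, though modestly. The leaving 2-hydroxyphenyl has 1 hydrogen-bond donor and 1 hydrogen-bond acceptor, while the entering 3,4-dimethylphenyl has 0 of each, so compound 4 at 10000 nM shows that a hydroxyl on this aryl group is not required for a number of this size on the core of compound 2. No supporting data are available to explain the shift, and this single exchange cannot separate the loss of the hydroxyl from the gain of the two methyl groups.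

From the compounds shown here alone, whether one methyl group alone, as in 3-methylphenyl or 4-methylphenyl, gives the same step remains open, as does the effect of an amine or a carboxylic acid on this aryl group. Also open, going by these compounds, is whether the step carries over to the methoxy-substituted compounds, compound 1 and compound 3.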